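This account rests on a few compounds, and the source may have more. Where it says the series, first, only, none or still open, it means among the compounds named here.

Values in a physicochemical assay for lipophilicity, using the shake flask method, in phosphate buffer, measured as octanol-water partition, with a stated time of 24 h, at pH 7.4 (on this read-out lower numbers stand for lower lipophilicity and higher numbers for higher lipophilicity), for the three measured compounds:
Compound 1 `Cc1nn(-c2ccccc2F)c2c1CCS(=O)(=O)O2` gives 1.86
Compound 2 `O=S1(=O)CCc2c(C3CC3)nn(-c3ccccc3F)c2O1` gives 2.09
Compound 3 `COc1ccc(-c2nn(-c3ccccc3F)c3c2CCS(=O)(=O)O3)cc1` gives 2.62

The nearest measured neighbour of compound 1 lies within the scatter, with cyclopropyl in place of methyl giving a number 0.23 log units higher from compound 1 to compound 2 (within the scatter). Compound 4 `Cc1cc(C2CS(=O)(=O)Oc3c2c(C)nn3-c2ccccc2F)ccc1Br` differs from compound 1 by 4-bromo-3-methylphenyl in place of hydrogen on a saturated ring carbon, with 4-bromo-3-methylphenyl in place of hydrogen on a saturated ring carbon. Within the data shown here, no measured step sits at that place, as both changes from compound 1 are on an aromatic carbon. The closest guide is the aryl change, with 4-methoxyphenyl in place of methyl giving a number 0.76 log units higher from compound 1 to compound 3 (beyond the scatter). There the aryl group replaces methyl, whereas here it replaces hydrogen and carries more heavy atoms. A larger rise in this assay, beyond the scatter, is therefore expected, an estimated a number 1.74 log units higher from compound 1 to compound 4 (beyond the scatter). Compound 4 is expected at 3.6, with an estimated range of 3 to 4.2.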

Compound 4, partition coefficient: 2.26
For compound 4 the middle estimate is 1.34 log units above the measured one; measured number below the stated range.
By their numbers in this assay, from the lowest: compounds 1, 2 and 4 (each within the scatter of the next, the first and the last beyond it); then compound 3.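

Compound 4 carries the only change shown on a saturated ring carbon, two ring bonds from the ring sulfur, as every earlier step lay on an aromatic carbon. In this assay, 4-bromo-3-methylphenyl in place of hydrogen there gives a number 0.40 log units higher from compound 1 to compound 4 (beyond the scatter), so an entering group of 8 heavy atoms produces only a modest step. Nothing measured here accounts for the size of that step.

The compounds shown leave open how an amine or a carboxylic acid would read at this carbon in this assay. They also leave open whether an unsubstituted phenyl would give a similar step.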